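A few compounds are considered here, and "the series" means these few. Any claim that something is new, unique, unknown or untested is made for them only; others in the source may bear on it.

The measured compounds:

compound 1, `Nc1ncnc2c1ncn2CC(O)C(=O)OCCO` — in a functional assay on Vero cells (Chlorocebus sabaeus) for cytotoxicity (on this read-out lower numbers stand for higher toxicity in this test and higher numbers for lower toxicity in this test), compound 1 gives > 400 ug/mL
compound 2, `Nc1ncnc2c1ncn2CC(O)C(=O)OC1CCCCC1` — compound 2 gives 100 ug/mL
compound 3, `CCCCCOC(=O)C(O)Cn1cnc2c(N)ncnc21` — compound 3 gives 200 ug/mL

Compound 3 holds the highest of the two numbers recorded in this assay; compound 2 is nearest, and a 2.0-fold higher number from compound 2 to compound 3 (0.30 log units; within the scatter) lies within the scatter. Compound 1 shows only a limit, > 400 ug/mL, not a number. Compound 4, `CCCOC(=O)C(O)Cn1cnc2c(N)ncnc21`, remains unmeasured; it differs from compound 3 by hydrogen in place of ethyl on a saturated chain carbon, three bonds along the chain from an oxygen next to a carbonyl group. Among the compounds with values here, the steps that bear on this change are those that alter the group on the oxygen next to the carbonyl group: an at least 4.0-fold lower number from compound 1 to compound 2 (0.60 log units; beyond the scatter), an at least 2.0-fold lower number from compound 1 to compound 3 (0.30 log units; that floor lies within the scatter) and a 2.0-fold higher number from compound 2 to compound 3 (0.30 log units; within the scatter). Within the data shown here, only the step from compound 1 to compound 2 clearly passes the scatter, and it runs toward a lower number when 2-hydroxyethyl gives way to cyclohexyl. Shortening pentyl to propyl is a smaller change than either of those, and the exchange of cyclohexyl for pentyl itself stayed within the scatter. For compound 4 the expected step is therefore a 1.5-fold higher number from compound 3 to compound 4 (0.18 log units; within the scatter), which does not pass beyond the scatter, with a slight lean toward a higher number. The estimate for compound 4 in this assay is 300 ug/mL, between 150 ug/mL and 600 ug/mL.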

Compound 4, minimum cytotoxic concentration: > 400 ug/mL
Compound 4: no number, only a limit; the forecaster's own chance of this, stated with the estimate: 30%; at least 1.3-fold (0.12 log units) between middle value and limit.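

In this assay compound 4 gives > 400 ug/mL, which is a limit and not a number. Going from pentyl to propyl, that is, hydrogen in place of ethyl on a saturated chain carbon, three bonds along the chain from an oxygen next to a carbonyl group, gives an at least 2.0-fold higher number from compound 3 to compound 4 (0.30 log units; that floor lies within the scatter), so this change can be stated only as a floor and its full size remains unknown. The firmer reading comes with cyclohexyl as the starting group: the earlier exchange of cyclohexyl for pentyl stayed within the scatter, whereas propyl in place of cyclohexyl gives an at least 4.0-fold higher number from compound 2 to compound 4 (0.60 log units; beyond the scatter), so the shorter chain separates from compound 2 in a way that pentyl did not.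

On these data alone, the step from compound 1 to compound 4 cannot be read, because both compounds sit at the same limit of the assay: the limit of > 400 ug/mL in this assay, at which 2 of the 4 values shown sit. Also open is what a butyl chain, or a longer chain such as octyl, would give on that oxygen in this assay, and so whether chain length follows any steady trend.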